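A few compounds are considered here, and "the series" means these few. Any claim that something is new, unique, unknown or untested is made for them only; others in the source may bear on it.

Working notes on a short series of linear polyamines in a functional assay on L1210 cells (Mus musculus) for inhibition, with a stated time of 48 h; a higher number here means a weaker inhibitor, a lower number a stronger inhibitor.

Compound 1 `CCCNCCCCNCCCN` and compound 2 `CCCNCCCCNCCCCN` differ by aminomethyl in place of amino on a saturated chain carbon, three bonds along the chain from an amine nitrogen. For compound 1 the result in this assay is only a limit, > 100000 nM. Compound 2 gives 100000 nM in this assay. The step of a number no higher from compound 1 to compound 2 (the limit leaves the size open) therefore cannot be sized. Compound 3 `NCCCCCNCCCCN` also returns only a limit in this assay, > 100000 nM. From the compounds shown here alone, the step of a number no lower from compound 2 to compound 3 (the limit leaves the size open) is likewise open in size. Among the compounds with values here, two of the three results rest at the limit of > 100000 nM in this assay, at which 2 of the 3 values shown sit, so the series shows no compound with measurable inhibition so far.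

Compound 4 `NCCCCCNCCCCCN` remains to be measured. From compound 3 it differs by aminomethyl in place of amino on a saturated chain carbon, four bonds along the chain from an amine nitrogen, the same kind of change as that from compound 1 to compound 2, here placed four bonds rather than three bonds along the chain from an amine nitrogen. How the core of compound 3 differs from the core of compound 1 is not broken down here.

Compound 4 is expected to give about 100000 nM in this assay, a step of a number no higher from compound 3 to compound 4 (the limit leaves the size open), most likely reported again as a limit. This expectation rests on compound 2 giving 100000 nM and on the open-sized step a number no higher from compound 1 to compound 2 (the limit leaves the size open), which together give no sign that lengthening a terminal aminomethyl arm brings potency into the measurable range.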

Compound 4, half-maximal inhibitory concentration: 100000 nM
Beside the measured number, compound 4's estimate shows no gap at the digits printed; measured number inside the range.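

The new result is a number no higher from compound 3 to compound 4 (the limit leaves the size open). Both steps of amino to aminomethyl are open in size, so the two cores can be set side by side only by the direction each limit allows: the same change on two cores in this assay, a number no higher (the limit leaves the size open) from compound 1 to compound 2 and a number no higher (the limit leaves the size open) from compound 3 to compound 4; the limit leaves it open whether they differ. Within the data shown here, no compound has a value that stands clear of the assay limit in this assay: the limit of > 100000 nM in this assay, at which 2 of the 4 values shown sit. The series therefore does not show that the change carries from one core to the other with the same size, nor that it does not, and it gives no sign of the change bringing inhibition into a clearly measurable range.

The compounds shown leave open whether any linear chain of this type reaches measurable inhibition in this assay. They also leave open what a longer chain between the amine nitrogens, or a carboxylic acid or hydroxyl in place of a terminal amine, would do on these cores.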